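Furan to Pyridine on a Shared Core

This account rests on a few compounds, and the source may have more. Where it says the series, first, only, none or still open, it means among the compounds named here.

Of the compounds shown here, three built on one shared core have been tested in an assay on isolated protein for inhibition of DNA topoisomerase 1 (Homo sapiens), with a stated time of 30 min, tested at 100 uM; a higher number here means a stronger effect of the compound at the concentration tested, a lower number a weaker effect. Compound 1 `Oc1cccc(-c2cc(-c3ccncc3)nc(-c3cccc(Cl)c3)c2)c1` gives 0%. Compound 2 `Oc1cccc(-c2cc(-c3ccccc3)nc(-c3ccccc3Cl)c2)c1` gives 3.2%. Compound 3 `Oc1cccc(-c2cc(-c3ccco3)nc(-c3ccccc3Cl)c2)c1` gives 0% in this assay. Compound 3 thus stands level with compound 1 at the digits shown, and the gap between compound 3 and compound 2 is within the scatter, so the three numbers cannot be told apart.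

Compound 4 `Oc1cccc(-c2cc(-c3ccncc3)nc(-c3ccccc3Cl)c2)c1` has not yet been measured. It differs from compound 3 in one place: pyridin-4-yl in place of furan-2-yl on an aromatic carbon.

For the measured compounds named here, one measured step bears on this change. The step of a number 3.2 percentage points lower from compound 2 to compound 3 (within the scatter) also exchanged one aromatic ring for another on the same aromatic carbon and stayed within the scatter. Compound 1, which carries a pyridin-4-yl group, shows 0%, which points the same way. No step beyond the scatter is therefore expected; the estimated step of no change at the digits printed from compound 3 to compound 4 (within the scatter) is none. Compound 4 is estimated at 0%, within a range from 0% to 8%.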

Compound 4, a percentage reported as inhibition, at one concentration (the size of the read-out at that concentration, not a potency): 0%
For compound 4 middle estimate and measured number coincide at the digits printed; measured number inside the range.
By their numbers in this assay, from the lowest: compounds 1, 3, 4 and 2 (each within the scatter of the next).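

In this assay, pyridin-4-yl now joins phenyl and furan-2-yl on the same aromatic carbon with the 2-chlorophenyl group held constant, and the exchanges give no change at the digits printed from compound 3 to compound 4 (within the scatter) and a number 3.2 percentage points lower from compound 2 to compound 4 (within the scatter), so these three aromatic rings cannot be told apart here. The other group can also be exchanged with pyridin-4-yl in place: 2-chlorophenyl for 3-chlorophenyl gives no change at the digits printed from compound 1 to compound 4 (within the scatter), so this shift of the chlorine leaves no readable difference either. Nothing available here offers an explanation for these readings.

As far as these compounds go, all of these groups at this position are aromatic rings, so it remains open whether a carboxylic acid or an aminomethyl chain there would give a read-out beyond the scatter. The 3-hydroxyphenyl group is the same throughout, so replacing its hydroxyl with a methoxy group or an amine also remains untested in what is shown.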